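Bromophenyl Position on Two Dimethoxy Cyclohexanone Cores

The source may report more compounds than this note shows. Statements on the series, on what has been measured and on what is new or still open speak of the compounds shown alone.

Compound 1 `COc1cccc(/C=C2\CCC/C(=C\c3cccc(Br)c3)C2=O)c1OC` and compound 2 `COc1cccc(/C=C2\CCC/C(=C\c3ccc(Br)cc3)C2=O)c1OC` share one core, while compound 3 `COc1ccc(/C=C2\CCC/C(=C\c3cccc(Br)c3)C2=O)cc1OC` and the unmeasured compound 4 `COc1ccc(/C=C2\CCC/C(=C\c3ccc(Br)cc3)C2=O)cc1OC` share another; the difference between the two cores is not broken down here. In a functional assay on A549 cells (Homo sapiens) for cytotoxicity, read by MTT assay, with a stated time of 72 h (on this read-out higher numbers stand for weaker inhibition and lower numbers for stronger inhibition), compound 1 gives > 20000 nM, which is a limit of the assay rather than a number. In this assay compound 2 likewise gives > 20000 nM, again a limit. In this assay, within the data shown here, compound 3 gives 12800 nM, the only number among the three measured values.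

The change from compound 1 to compound 2 is 4-bromophenyl in place of 3-bromophenyl on a double-bonded chain carbon bound to a double-bonded ring carbon. Its step, a step that the two limits leave unreadable from compound 1 to compound 2, cannot be read because both ends sit at the limit of > 20000 nM in this assay, at which 2 of the 3 values shown sit. The same change carries compound 3 to compound 4: 4-bromophenyl in place of 3-bromophenyl on a double-bonded chain carbon bound to a double-bonded ring carbon. The place of the change is described in the same words for both pairs, so it is the same change, not merely the same kind.

With the earlier step unreadable, no measured size is available to carry over. Since compound 3 gives 12800 nM, the step expected is a 1.2-fold higher number from compound 3 to compound 4 (0.07 log units; within the scatter), essentially flat within the usual scatter. Compound 4 is therefore estimated at about 15000 nM in this assay, expected to fall between 6000 nM and 35000 nM.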

Compound 4, half-maximal inhibitory concentration: 16000 nM
For compound 4 the middle estimate is 1.1-fold (0.03 log units) below the measured one; the measured number falls inside the stated range.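

In this assay, putting 4-bromophenyl in place of 3-bromophenyl on the core of compound 3 gives a 1.3-fold higher number from compound 3 to compound 4 (0.10 log units; within the scatter), so on this core the two bromophenyl groups cannot be told apart on this read-out. On the core of compound 1 the same change cannot be read, because compound 1 and compound 2 both sit at a limit of the assay rather than at a number: the limit of > 20000 nM in this assay, at which 2 of the 4 values shown sit. Among these compounds, the account therefore holds only one readable step, which shows that the change makes no difference beyond the scatter on one core, but it does not show that the change carries from one core to the other, since there is no second size to set against it.

The compounds shown leave open how the change would read on the core of compound 1 if both of its compounds gave numbers, and how far the difference between the two cores matters, since that difference is not broken down here. They also leave open what a group other than bromine would do on the phenyl ring at the same place, such as an amine or a carboxylic acid.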